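This account rests on a few compounds, and the source may have more. Where it says the series, first, only, none or still open, it means among the compounds named here.

Measured compounds in a functional assay on MCF7 cells (Homo sapiens) for antiproliferative activity, read by sulforhodamine B assay, with a stated time of 48 h; a higher number here means a weaker inhibitor of growth, a lower number a stronger inhibitor of growth:

- compound 1, `CCN(CC)CCCNc1ccnc2cc(Cl)ccc12`: 17900 nM
- compound 2, `O=C1C(=O)N(CCCNc2ccnc3cc(Cl)ccc23)c2cc(Br)ccc21`: 16600 nM
- compound 3, `CCN(CC)CCCNc1ccnc2cc(C(F)(F)F)ccc12`: 20600 nM

Compound 3 sits with the other two: the step from compound 1 to compound 3, trifluoromethyl in place of chloro on an aromatic carbon, is a 1.2-fold higher number from compound 1 to compound 3 (0.06 log units; within the scatter). No step is computed between compound 2 and compound 3, but their values in this assay lie within the scatter of each other, so nothing separates the three compounds on the numbers shown.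

Compound 4, `CN1CCN(CCCNc2ccnc3cc(C(F)(F)F)ccc23)CC1`, is not yet measured. It differs from compound 3 by 4-methylpiperazin-1-yl in place of diethylamino on a saturated chain carbon, three bonds along the chain from a nitrogen on an aromatic ring. For the measured compounds named here, none of the measured steps touches this part of the molecule; the only measured step, from compound 1 to compound 3, changes the aromatic substituent and stays within the scatter. Going by the values given here, with the three measured values so close and no step on the amine end, no movement beyond the scatter is expected in this assay. Compound 4 is therefore expected near compound 3, at 19000 nM, between 8000 nM and 45000 nM, an estimated step of a 1.1-fold lower number from compound 3 to compound 4 (0.04 log units; within the scatter).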

Compound 4, concentration for 50% growth inhibition: 30800 nM
Estimate against measurement, compound 4: 1.6-fold (0.21 log units) below; low and high end bracket the measured number.
By their numbers in this assay, from the lowest: compounds 2, 1, 3 and 4 (each within the scatter of the next).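

For the compounds shown here, this is the first measured step at the amine end of the chain: in this assay, 4-methylpiperazin-1-yl in place of diethylamino gives a 1.5-fold higher number from compound 3 to compound 4 (0.17 log units; within the scatter). At this place on the saturated chain, then, an open diethylamino group of 5 heavy atoms can give way to a six-membered non-aromatic ring of 7 heavy atoms, with a second nitrogen, without a change beyond the scatter, at least with trifluoromethyl on the core. No measurement at hand bears on why this step is as small as it is.

On these data alone, whether the same exchange stays as small with chloro on the core, as in compound 1, remains open. Also open, as far as these compounds go, is whether another amine end, such as morpholin-4-yl or a primary amine, or a longer chain would move the number beyond the scatter.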